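Fluoro Added to Compound 2: Expected Growth Inhibition

A few compounds are considered here, and "the series" means these few. Any claim that something is new, unique, unknown or untested is made for them only; others in the source may bear on it.

Compound 1 `C/C(=N\Nc1nc(-c2ccc(F)cc2)cs1)c1sc(C)nc1C`: in a toxicity assay on MCF7 cells (Homo sapiens) for cytotoxicity, read by MTT assay (a higher number here means a weaker inhibitor of growth, a lower number a stronger inhibitor of growth), compound 1 gives > 100 ug/mL, which is a limit of the assay and not a number.
Compound 2 `C/C(=N\Nc1nc(-c2ccccc2)cs1)c1sc(-c2ccccc2)nc1C`: in this assay compound 2 gives > 100 ug/mL, again a limit of the assay.

Compound 2 thus stands at the limit, where both measured values sit, as the limit of > 100 ug/mL in this assay, at which 2 of the 2 values shown sit, shows. Among the measured compounds shown here, no step between measured compounds is available. Compound 3 `C/C(=N\Nc1nc(-c2ccc(F)cc2)cs1)c1sc(-c2ccccc2)nc1C` differs from compound 2 by fluoro in place of hydrogen on an aromatic carbon. With both known values at the limit, compound 3 is expected to show no step beyond the scatter, so a step that the limit leaves unreadable from compound 2 to compound 3 is the expected change. Compound 3 is estimated at 150 ug/mL, from 60 ug/mL to 400 ug/mL.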

Compound 3, concentration for 50% growth inhibition: > 100 ug/mL
Compound 3: no number, only a limit; the forecaster's own chance of this, stated with the estimate: 85%; the middle value does not contradict the limit.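

Among the compounds shown here, compound 3 gives only a limit of the assay, so no step from compound 1 or compound 2 to compound 3 can be read: the limit of > 100 ug/mL in this assay, at which 3 of the 3 values shown sit. The compounds shown leave open whether fluoro in place of hydrogen, or phenyl in place of methyl, changes growth inhibition in this assay at all.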